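Ortho methoxy in place of trifluoromethyl on the anilino ring

A few compounds are considered here, and "the series" means these few. Any claim that something is new, unique, unknown or untested is made for them only; others in the source may bear on it.

Of the compounds shown here, three sharing one core have been tested in a functional assay on MGC-803 cells (Homo sapiens) for cytotoxicity, read by MTT assay, with a stated time of 72 h; a lower number here means a stronger inhibitor, a higher number a weaker inhibitor. Compound 1 `CCCCCCNc1nc(SCc2ccc(C(F)(F)F)cc2)nc2ccccc12` carries a hexyl chain on the ring nitrogen and gives 13100 nM. Compound 2 `FC(F)(F)c1ccc(CSc2nc(Nc3ccccc3)c3ccccc3n2)cc1` carries a phenyl there and gives 22200 nM; the move a 1.7-fold higher number from compound 1 to compound 2 (0.23 log units; within the scatter). From the compounds shown here alone, compound 3 `FC(F)(F)c1ccc(CSc2nc(Nc3ccccc3C(F)(F)F)c3ccccc3n2)cc1` carries a 2-(trifluoromethyl)phenyl and reaches only the assay limit, > 50000 nM, so its true number is unknown (the limit of > 50000 nM in this assay, at which 1 of the 3 values shown sits). Compared with the others, the steps of an at least 3.8-fold higher number from compound 1 to compound 3 (0.58 log units; beyond the scatter) and an at least 2.2-fold higher number from compound 2 to compound 3 (0.35 log units; beyond the scatter) both weaken inhibition beyond the scatter, placing compound 3 as the weakest of the three shown.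

Compound 4 `COc1ccccc1Nc1nc(SCc2ccc(C(F)(F)F)cc2)nc2ccccc12` differs from compound 3 by one change: methoxy in place of trifluoromethyl on an aromatic carbon. Among the compounds with values here, the only steps that bear on it are those leading to compound 3, which show that a substituent at this position costs potency relative to compound 2. Whether the smaller methoxy costs as much as the trifluoromethyl cannot be read from these three compounds. Compound 4 is therefore expected to sit between compound 2 and compound 3, at an estimated 30000 nM (range 12000 nM to 75000 nM), which would mean a step of an at least 1.6-fold lower number from compound 3 to compound 4 (0.22 log units; that floor lies within the scatter) in this assay.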

Compound 4, half-maximal inhibitory concentration: > 50000 nM
Compound 4 gave a limit, no number; the forecaster's own chance of this, stated with the estimate: 35%; at least 1.6-fold (0.22 log units) between middle value and limit.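

In this assay, a methoxy on this aromatic carbon also weakens inhibition: an at least 2.2-fold higher number from compound 2 to compound 4 (0.35 log units; beyond the scatter), and an at least 3.8-fold higher number from compound 1 to compound 4 (0.58 log units; beyond the scatter). The loss seen with trifluoromethyl therefore extends to a second, different group at this place, although the step between compound 3 and compound 4 cannot be read, as each of the two values is a limit rather than a number. With compound 4, the set now has two compounds with a substituent at this place, and both stand at the limit: the limit of > 50000 nM in this assay, at which 2 of the 4 values shown sit.

From the compounds shown here alone, how far either compound lies past that limit remains unknown, so the two groups cannot be ranked against each other. Also open, going by these compounds, is whether a fluorine atom, a methyl or an amine on this same carbon would give a readable value.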